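The source may report more compounds than this note shows. Statements on the series, on what has been measured and on what is new or still open speak of the compounds shown alone.

Measured compounds:
Compound 1 `CC(=O)Nc1cc(-c2ccc(OC[C@@H](N)CC(C)C)c(Cl)c2)ccn1` gives 0.2 nM in an assay on HEK293F cells for inhibition of AP2-associated protein kinase 1 (Homo sapiens), read by Western blot, with a stated time of 3 h; on this read-out lower numbers stand for stronger inhibition and higher numbers for weaker inhibition.
Compound 2 `COC(=O)Nc1cc(-c2cc(C)c(OC[C@@](C)(N)CC(C)C)cn2)ccn1` gives 12 nM in this assay.

Compound 1 holds the lower of the two numbers recorded so far, and compound 2 sits well above it, a gap far beyond the scatter of repeated measurements. The two compounds differ in several places at once, so no single structural change can be matched to that gap; only the two values themselves are known.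

Compound 3 `CC(=O)Nc1cc(-c2ccc(OC[C@@H](N)CC(C)C)c(C)c2)ccn1` is a close relative of compound 1. The change is methyl in place of chloro on an aromatic carbon. One small group is swapped for another of the same size, with no change in donors, acceptors or charge, on the same ring of the shared core. Among the measured compounds shown here, no measured pair shows this particular swap, so its effect can only be guessed. Such a small exchange is expected to move the number little, if at all: compound 3 is expected to land at about 0.35 nM, somewhere between 0.1 nM and 1.2 nM, which means an expected step of a 1.8-fold higher number from compound 1 to compound 3 (0.24 log units; within the scatter), at most a mild weakening and possibly none beyond the scatter.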

Compound 3, half-maximal inhibitory concentration: 1.1 nM
Compound 3: middle estimate off by 3.1-fold (0.50 log units), on the low side; the measured number falls inside the stated range.
By their numbers in this assay, from the lowest: compound 1; then compound 3; then compound 2.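

In this assay the change of chloro to methyl on this aromatic carbon, ortho to the (2-amino-4-methylpentyl)oxy group, gives a 5.5-fold higher number from compound 1 to compound 3 (0.74 log units; beyond the scatter) and so shows that this position is not indifferent to which of these two groups it carries. This is the first pair shown that differs in only one place, and the step, though modest, lies beyond the usual scatter even though both groups have the same count of heavy atoms, hydrogen-bond donors and hydrogen-bond acceptors and neither carries a net charge, so those counts alone do not tell the two groups apart. No measurement shown here accounts for the lower number that goes with chloro.

The compounds shown carry only chloro and methyl at this place, so how a plain hydrogen, a fluoro, a methoxy or a nitrile there would read remains open. As far as these compounds go, with just one pair showing this swap, it also remains open whether the step would keep its size on a different core or with a different group on the rest of the molecule.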